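The source may report more compounds than this note shows. Statements on the series, on what has been measured and on what is new or still open speak of the compounds shown alone.

For the measured compounds named here, in a functional assay on MCF7 cells (Homo sapiens) for antiproliferative activity, read by MTT assay, with a stated time of 48 h (a higher number here means a weaker inhibitor, a lower number a stronger inhibitor), compound 3 `O=C(CN1CCCCC1)Nc1ccc2ncnc(Nc3cccc(Br)c3)c2c1` gives 3000 nM, the lowest number measured so far. Compound 2 `O=C(CN1CCCC1)Nc1ccc2ncnc(Nc3cccc(Br)c3)c2c1` gives 12000 nM. Compound 1 `CN1CCN(CC(=O)Nc2ccc3ncnc(Nc4cccc(C(F)(F)F)c4)c3c2)CC1`, which also bears 4-methylpiperazin-1-yl, reads > 100000 nM, and this is a limit of the assay, not a number.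

Compound 4 `CN1CCN(CC(=O)Nc2ccc3ncnc(Nc4cccc(Br)c4)c3c2)CC1` has 4-methylpiperazin-1-yl in place of piperidin-1-yl on a saturated chain carbon bound to a carbonyl carbon. Going by the values given here, the one measured step that changes a ring at this place is a 4.0-fold lower number from compound 2 to compound 3 (0.60 log units; beyond the scatter). It is a modest step and a different swap, so it suggests the likely size of a change here but not its direction. The direction rests on compound 1 at > 100000 nM, again a limit, which points to a higher number in this assay. A modest weakening, similar in size to the measured step, is therefore expected.

The expected change is a 5.0-fold higher number from compound 3 to compound 4 (0.70 log units; beyond the scatter). For compound 4, the estimated value is 15000 nM, with an expected range of 3000 nM to 80000 nM.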

Compound 4, half-maximal inhibitory concentration: 10000 nM
For compound 4 the middle estimate is 1.5-fold (0.18 log units) above the measured one; measured number inside the range.
By their numbers in this assay, from the lowest: compound 3; then compounds 4 and 2 (each within the scatter of the next). At a limit, above all of these: compound 1.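

In this assay, with bromo kept on the aromatic carbon, three rings can now be compared on the saturated chain carbon bound to a carbonyl carbon, and piperidin-1-yl stands apart from the other two: the swap to 4-methylpiperazin-1-yl gives a 3.3-fold higher number from compound 3 to compound 4 (0.52 log units; beyond the scatter), whereas the swap from pyrrolidin-1-yl gives a 1.2-fold lower number from compound 2 to compound 4 (0.08 log units; within the scatter), so these two rings cannot be told apart here. With 4-methylpiperazin-1-yl kept in place, changing the aromatic group gives an at least 10-fold lower number from compound 1 to compound 4 (1.00 log units; beyond the scatter). The true size of that step is unknown, as it rests on a limit of the assay and not on a number: the limit of > 100000 nM in this assay, at which 1 of the 4 values shown sits.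

The compounds shown leave open where morpholin-4-yl or an open-chain dimethylamino group would fall at this place. They also leave open whether piperidin-1-yl would keep its edge with trifluoromethyl in place of bromo.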